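The compounds below may be only part of what the source reports. "The series", "measured", "known", "first", "only" and "open" are said of these compounds alone.

Compound 3 `COc1ccc(C(=O)c2ccccc2OC)cc1OCC(=O)OC[C@@H]1C=C[C@H](n2cc(C)c(=O)[nH]c2=O)O1` sits second highest among the three numbers recorded in a functional assay on HeLa cells (Homo sapiens) for antiproliferative activity, read by MTT assay, with a stated time of 48 h (on this read-out higher numbers stand for weaker inhibition and lower numbers for stronger inhibition), where compound 3 gives 30200 nM. Its neighbours are compound 1 `COc1ccc(C(=O)c2ccc(F)cc2)cc1OCC(=O)OC[C@@H]1C=C[C@H](n2cc(C)c(=O)[nH]c2=O)O1`, which in this assay gives 36300 nM, and compound 2 `COc1ccc(C(=O)c2ccc([N+](=O)[O-])cc2)cc1OC(=O)CCC(=O)OC[C@@H]1C=C[C@H](n2cc(C)c(=O)[nH]c2=O)O1`, which gives 21100 nM. Both gaps to compound 3 fall within the usual scatter, so these three cannot be ranked against one another on the numbers shown.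

Compound 4 `COc1ccc(C(=O)c2ccc([N+](=O)[O-])cc2)cc1OCC(=O)OC[C@@H]1C=C[C@H](n2cc(C)c(=O)[nH]c2=O)O1` has not yet been measured. Relative to compound 3 it differs in one place: 4-nitrophenyl in place of 2-methoxyphenyl on a carbonyl carbon. For the measured compounds named here, only one measured step touches the same spot, namely a 1.2-fold lower number from compound 1 to compound 3 (0.08 log units; within the scatter). That swap of one ring for another on the carbonyl carbon left the number essentially unchanged. Compound 2 also carries a 4-nitrophenyl group on its carbonyl carbon, but its link to the shared core is built differently, so no single-change comparison with compound 3 exists; its value simply shows another number of similar size.

On this basis the change from compound 3 to compound 4 is expected to be small, a 1.2-fold lower number from compound 3 to compound 4 (0.08 log units; within the scatter), with no clear direction beyond the scatter. Compound 4 is therefore estimated at 25000 nM, with a likely range from 12000 nM to 50000 nM.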

Compound 4, half-maximal inhibitory concentration: 50200 nM
The estimate for compound 4 lay 2.0-fold (0.30 log units) below the measured number, and the stated range ends below it.
By their numbers in this assay, from the lowest: compounds 2, 3, 1 and 4 (each within the scatter of the next, the first and the last beyond it).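

In this assay, the rings 2-methoxyphenyl, 4-fluorophenyl and 4-nitrophenyl can now be compared on the same carbonyl carbon with the same link to the shared core, and the new result gives a 1.7-fold higher number from compound 3 to compound 4 (0.22 log units; within the scatter) for the exchange of a whole ring. The closer comparison is a 1.4-fold higher number from compound 1 to compound 4 (0.14 log units; within the scatter), in which the ring stays and only nitro replaces fluoro on an aromatic carbon, so that two different kinds of swap at this position now both stay inside the scatter, a statement that holds for these compounds only. No measured finding is available that could explain the small differences among these numbers.

The compounds shown leave open whether any change at this position can move the number beyond the scatter, for instance an amine or a carboxylic acid on the ring, or a simple methyl in place of the whole ring. They also leave open whether the ring matters at all for activity in this assay, since every ring tested so far gives a number that cannot be told apart from its neighbours in a single step.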